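Carboxymethyl for vinyl on the sulfur-bound chain of a uridine diphosphate

A few compounds are considered here, and "the series" means these few. Any claim that something is new, unique, unknown or untested is made for them only; others in the source may bear on it.

Three uridine diphosphate analogues have been measured in an in vitro functional assay on 1321-N1 cells for agonist activity at P2Y purinoceptor 6 (Homo sapiens); on this read-out higher numbers stand for an effect only at larger amounts of compound and lower numbers for an effect already at smaller amounts. Compound 1 `O=c1ccn([C@@H]2O[C@H](COP(=O)(O)OP(=O)(O)O)[C@@H](O)[C@H]2O)c(=S)[nH]1` gives 60 nM. Compound 2 `C=CCSc1ccn([C@@H]2O[C@H](COP(=O)(O)OP(=O)(O)O)[C@@H](O)[C@H]2O)c(=O)n1` gives 560 nM, and compound 3 `O=c1ccn([C@@H]2O[C@@]3(COP(=O)(O)OP(=O)(O)O)C[C@H]3[C@H]2O)c(=O)[nH]1` gives 3500 nM. Among these three numbers compound 2 stands second highest: its nearest neighbour is compound 3, with a higher number beyond the scatter, and its furthest is compound 1, with a lower number beyond the scatter.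

The piece now turns to compound 4 `O=C(O)CCSc1ccn([C@@H]2O[C@H](COP(=O)(O)OP(=O)(O)O)[C@@H](O)[C@H]2O)c(=O)n1`, which has not yet been measured in this assay. It differs from compound 2 in one place: carboxymethyl in place of vinyl on a saturated chain carbon bound to a sulfur. Cut one bond further out, the same difference reads allyl to 2-carboxyethyl, or allylsulfanyl to (2-carboxyethyl)sulfanyl.

Within the data shown here, no measured pair in this set shows what such an exchange does on this read-out, so the expectation rests on compound 2 alone, with 560 nM as the anchor. The step of a 1.6-fold higher number from compound 2 to compound 4 (0.21 log units; within the scatter) is expected to be modest, toward a somewhat higher number, and it may well stay within the scatter. Compound 4 is therefore estimated at 900 nM in this assay, with a range from 300 nM to 3000 nM.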

Compound 4, half-maximal effective concentration: 1100 nM
Compound 4: the middle estimate sits 1.2-fold (0.09 log units) below what was measured; the range from low to high includes it.
By their numbers in this assay, from the lowest: compound 1; then compounds 2 and 4 (each within the scatter of the next); then compound 3.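

In this assay, among these compounds, carboxymethyl in place of vinyl on a saturated chain carbon bound to a sulfur gives a 2.0-fold higher number from compound 2 to compound 4 (0.29 log units; within the scatter) and is the first reading of any exchange at this place. The step lies within the scatter, so on this read-out compound 2 and compound 4 cannot be told apart, even though the entering carboxymethyl brings more heavy atoms, a hydrogen-bond donor and a hydrogen-bond acceptor that vinyl lacks. This single pair shows that, on this chain, these added features go with no change that can be read, but no supporting measurement is available to explain that outcome.

The compounds shown leave open what an amine, a methyl ester or a longer chain ending in a carboxylic acid would do at this place, since one pair cannot show how far the chain end can be varied. They also leave open whether a chain with a benzyl group on the sulfur would read alike, or whether an oxygen in place of that sulfur would alter the picture.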